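Shortening the carbamate chain in a platelet-activating factor series

This account rests on a few compounds, and the source may have more. Where it says the series, first, only, none or still open, it means among the compounds named here.

Compound 1: `CCCCCC(=O)OCC1CN(C(=O)c2cc(OC)c(OC)c(OC)c2)CCN1C(=O)c1cc(OC)c(OC)c(OC)c1` — 290 nM
Compound 2: `CCCCCCCCNC(=O)OCC1CN(C(=O)c2cc(OC)c(OC)c(OC)c2)CCN1C(=O)c1cc(OC)c(OC)c(OC)c1` — 370 nM

Both compounds share one core and differ only in the group attached to the carbonyl of the side chain. In a functional assay (Oryctolagus cuniculus) for inhibition of platelet-activating factor receptor (Cavia porcellus) (a lower number here means a stronger inhibitor, a higher number a weaker inhibitor), compound 1 gives 290 nM, and compound 2 gives 370 nM. The step of a 1.3-fold higher number from compound 1 to compound 2 (0.11 log units; within the scatter) lies within the scatter, so the two values cannot be told apart; compound 2 simply has the higher of the two numbers shown, and that number sits within the scatter of compound 1.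

Compound 3 is `CCC(CC)NC(=O)OCC1CN(C(=O)c2cc(OC)c(OC)c(OC)c2)CCN1C(=O)c1cc(OC)c(OC)c(OC)c1`. It differs from compound 2 by pentan-3-yl in place of octyl on an amide-type nitrogen. Among the measured compounds shown here, the only measured step that bears on this change is the one from compound 1 to compound 2, a 1.3-fold higher number from compound 1 to compound 2 (0.11 log units; within the scatter), which replaced one chain by another at the same carbonyl and left the number within the scatter. On that evidence, the step of a 1.1-fold lower number from compound 2 to compound 3 (0.02 log units; within the scatter) is expected to stay within the scatter as well. Compound 3 is therefore estimated at 350 nM in this assay, with a range from 150 nM to 900 nM.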

Compound 3, half-maximal inhibitory concentration: 130 nM
Beside the measured number, compound 3's estimate is 2.7-fold (0.43 log units) above it; the whole stated range lies above it.
By their numbers in this assay, from the lowest: compound 3; then compounds 1 and 2 (each within the scatter of the next).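

Compound 3 shows that the group on this amide-type nitrogen can shift the number in this assay after all: with pentan-3-yl in place of octyl, the number falls (a 2.8-fold lower number from compound 2 to compound 3 (0.45 log units; beyond the scatter)). The comparison with compound 1 adds a second point: (pentan-3-yl)amino in place of pentyl on the carbonyl carbon also gives a lower number (a 2.2-fold lower number from compound 1 to compound 3 (0.35 log units; beyond the scatter)), whereas octylamino in that place gave a step lost in the scatter (a 1.3-fold higher number from compound 1 to compound 2 (0.11 log units; within the scatter)), so bringing in an amino link does not by itself lower the number, and the group on the nitrogen matters. No measurement here explains why this change lowers the number.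

Pentan-3-yl differs from octyl both in having fewer carbons and in being branched, so these compounds leave open which of the two differences goes with the lower number. An unbranched pentyl chain on the same nitrogen would separate the two, while a cyclopentyl ring or a chain ending in an amine would show whether other groups are accepted at this position.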